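A few compounds are considered here, and "the series" means these few. Any claim that something is new, unique, unknown or untested is made for them only; others in the source may bear on it.

Growth inhibition in a functional assay on HT-29 cells (Homo sapiens) for inhibition, read by MTT assay, with a stated time of 72 h (a higher number here means a weaker inhibitor of growth, a lower number a stronger inhibitor of growth), measured so far:

- compound 1 `COc1ccc(CNCCCNS(=O)(=O)c2cc(C(F)(F)F)cc(C(F)(F)F)c2)cc1OC` — 2700 nM
- compound 2 `O=S(=O)(NCCCNCc1cccc(Cl)c1)c1cc(C(F)(F)F)cc(C(F)(F)F)c1` — 14000 nM
- compound 3 `O=S(=O)(NCCCNCc1ccc(Br)cc1)c1cc(C(F)(F)F)cc(C(F)(F)F)c1` — 2200 nM

Compound 3 gives the lowest number of the three in this assay, though its gap to compound 1 is within the scatter, a 1.2-fold lower number from compound 1 to compound 3 (0.09 log units; within the scatter), so the two cannot be ordered. Only compound 2 stands clearly apart: a 6.4-fold lower number from compound 2 to compound 3 (0.80 log units; beyond the scatter), and likewise a 5.2-fold higher number from compound 1 to compound 2 (0.71 log units; beyond the scatter).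

Compound 4 `O=S(=O)(NCCCNCc1ccc(Cl)c(Cl)c1)c1cc(C(F)(F)F)cc(C(F)(F)F)c1` is not yet measured. It differs from compound 3 by 3,4-dichlorophenyl in place of 4-bromophenyl on a saturated chain carbon bound to an amine nitrogen. Within the data shown here, the one step that bears on it directly is the exchange of 3-chlorophenyl for 4-bromophenyl, a 6.4-fold lower number from compound 2 to compound 3 (0.80 log units; beyond the scatter); the 3,4-dichlorophenyl of compound 4 keeps a halogen at the position shared with 4-bromophenyl and adds the chlorine of compound 2. Nothing in the series tells how these two combine. The expectation is therefore a number close to compound 3, with no step beyond the scatter, a 1.1-fold higher number from compound 3 to compound 4 (0.06 log units; within the scatter). For compound 4 the estimate is 2500 nM, with a range from 900 nM to 7000 nM.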

Compound 4, concentration for 50% growth inhibition: 4700 nM
The estimate for compound 4 lay 1.9-fold (0.27 log units) below the measured number, and the stated range covers the measured number.
By their numbers in this assay, from the lowest: compounds 3, 1 and 4 (each within the scatter of the next, the first and the last beyond it); then compound 2.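

In this assay, among these compounds, chloro in place of hydrogen on an aromatic carbon gives a 3.0-fold lower number from compound 2 to compound 4 (0.47 log units; beyond the scatter), the first step that adds a single group to an existing ring, and it closes much of the gap left by the 3-chlorophenyl of compound 2. That recovery is incomplete, since 3,4-dichlorophenyl in place of 4-bromophenyl gives a 2.1-fold higher number from compound 3 to compound 4 (0.33 log units; beyond the scatter), a modest step but beyond the scatter, while a 1.7-fold higher number from compound 1 to compound 4 (0.24 log units; within the scatter) stays within the scatter and leaves those two compounds unordered. No measurement bears on why these changes have these effects.

From the compounds shown here alone, whether 4-chlorophenyl would track with compound 3 or with compound 4 remains open, so the contribution of the added chlorine cannot be separated from that of bromine versus chlorine. Also open, going by these compounds, is whether these steps would hold on a longer chain.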